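The source may hold more compounds than are shown below. What is called first, only, known or untested is meant among the compounds shown, and "the series" means these compounds.

Working notes on the series. Compound 1 `CC1(C)CC(=O)OC(CSc2nc(-c3ccccc3)c(-c3ccccc3)[nH]2)C1` gives 100 nM in an assay on microsomes from liver for inhibition of sterol O-acyltransferase 1 (Rattus norvegicus); a lower number here means a stronger inhibitor, a higher number a weaker inhibitor. Compound 2 `c1ccc(-c2nc(SCC3OCCO3)[nH]c2-c2ccccc2)cc1` gives 530 nM in this assay, and compound 3 `c1ccc(-c2nc(SCC3CCCCC3)[nH]c2-c2ccccc2)cc1` gives 100 nM in this assay. The three measured steps read: a 5.3-fold higher number from compound 1 to compound 2 (0.72 log units; beyond the scatter); no change at the digits printed from compound 1 to compound 3 (within the scatter); a 5.3-fold lower number from compound 2 to compound 3 (0.72 log units; beyond the scatter). Compound 3 therefore stands level with compound 1 at the digits shown, the two of them together giving the lowest numbers of the three, while compound 2 sits beyond the scatter from both.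

Compound 4 `c1ccc(CSc2nc(-c3ccccc3)c(-c3ccccc3)[nH]2)cc1` differs from compound 3 by phenyl in place of cyclohexyl on a saturated chain carbon bound to a sulfur. Among the compounds with values here, no measured step exchanges a saturated ring for an aromatic ring at this place. Within the data shown here, the steps that bear on it are no change at the digits printed from compound 1 to compound 3 (within the scatter), which stayed within the scatter, and a 5.3-fold lower number from compound 2 to compound 3 (0.72 log units; beyond the scatter), which was modest; together they show that the group on this saturated chain carbon moves the number by at most a modest amount, and that a six-membered ring of carbon only here belongs with the low numbers. A ring of the same size and the same carbon count is kept in compound 4, so no change beyond the scatter is expected, no change at the digits printed from compound 3 to compound 4 (within the scatter). For compound 4 the expected value is 100 nM, with a range from 40 nM to 300 nM.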

Compound 4, half-maximal inhibitory concentration: 290 nM
Compound 4: the middle estimate sits 2.9-fold (0.46 log units) below what was measured; measured number inside the range.
By their numbers in this assay, from the lowest: compounds 1 and 3 (each within the scatter of the next); then compounds 4 and 2 (each within the scatter of the next).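

At this place, on a saturated chain carbon bound to a sulfur, ring size and carbon count do not settle the number in this assay: with both kept, phenyl in place of cyclohexyl gives a 2.9-fold higher number from compound 3 to compound 4 (0.46 log units; beyond the scatter). Phenyl also separates from the group of compound 1, with a 2.9-fold higher number from compound 1 to compound 4 (0.46 log units; beyond the scatter), whereas a 1.8-fold lower number from compound 2 to compound 4 (0.26 log units; within the scatter) leaves phenyl and 1,3-dioxolan-2-yl unresolved, so among these four compounds the two six-membered non-aromatic rings stand together at the low end and neither the aromatic ring nor the five-membered ring joins them. Nothing at hand accounts for the difference that an aromatic ring makes here.

From the compounds shown here alone, what an amine, a carboxylic acid or a longer open alkyl chain would do on this saturated chain carbon remains open, as does whether a chlorine or a methoxy group on the phenyl ring would move compound 4 towards compound 3. Also open, going by these compounds, is whether the same ranking of these groups would hold with any change to the shared core, which stays the same in all four compounds.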